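Adding a chloro group: compound 2 to compound 3

The source may hold more compounds than are shown below. What is called first, only, known or untested is meant among the compounds shown, and "the series" means these compounds.

Measured so far:
compound 1 `O=C(O)c1nn(Cc2cc(Cl)c(Cl)cc2Cl)c2ccccc12`: 248 mg/kg
compound 2 `O=C(OCC(O)CO)c1nn(Cc2ccc(Cl)cc2Cl)c2ccccc12`: 69 mg/kg

Two compounds carry numbers in a functional assay on the whole organism (Testis, strain Long-Evans) with Rattus norvegicus as the target, with a stated time of 5 days; a higher number here means that more compound is needed for the effect, a lower number that less compound is needed. Compound 2 `O=C(OCC(O)CO)c1nn(Cc2ccc(Cl)cc2Cl)c2ccccc12` gives 69 mg/kg and stands lowest of the two; its nearest neighbour, compound 1 `O=C(O)c1nn(Cc2cc(Cl)c(Cl)cc2Cl)c2ccccc12`, gives 248 mg/kg in this assay, a gap that lies beyond the usual scatter. The two measured compounds differ from one another at more than one place, so no single change can be read from that gap.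

Compound 3 `O=C(OCC(O)CO)c1nn(Cc2cc(Cl)c(Cl)cc2Cl)c2ccccc12` is not yet measured. It differs from compound 2 in one place: chloro in place of hydrogen on an aromatic carbon. Among the compounds with values here, with no measured pair showing this change on its own, the expectation rests on the single comparison available, and that comparison is mixed. The step from compound 2 to compound 3 is therefore expected to be modest, the number for compound 3 likely somewhat higher than that of compound 2, a 1.4-fold higher number from compound 2 to compound 3 (0.16 log units; within the scatter), and possibly within the scatter. For compound 3, the estimate in this assay is 100 mg/kg, in a range from 40 mg/kg to 250 mg/kg.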

Compound 3, minimum effective dose: 300 mg/kg
For compound 3 the middle estimate is 3.0-fold (0.48 log units) below the measured one; measured number above the stated range.
By their numbers in this assay, from the lowest: compound 2; then compounds 1 and 3 (each within the scatter of the next).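

In this assay the chloro group that turns 2,4-dichlorophenyl into 2,4,5-trichlorophenyl can now be read on its own, and the step is a 4.3-fold higher number from compound 2 to compound 3 (0.64 log units; beyond the scatter), which lies beyond the usual scatter for a change on an aromatic carbon that is ortho to a chloro group and para to a chloro group. With that chloro group in place, the 2,3-dihydroxypropyl on the oxygen next to a carbonyl group gives a 1.2-fold higher number from compound 1 to compound 3 (0.08 log units; within the scatter), within the scatter, so the ester and the carboxylic acid cannot be told apart among the compounds that carry 2,4,5-trichlorophenyl. Nothing available here accounts for the size of the chloro step.

From the compounds shown here alone, the step is known on the 2,3-dihydroxypropyl ester alone, so whether the chloro group would count for as much on the carboxylic acid remains open. Also open, going by these compounds, is whether a fluoro, a methyl or a methoxy group in the same place would bring a step of similar size, or whether only chloro does so.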